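A few compounds are considered here, and "the series" means these few. Any claim that something is new, unique, unknown or untested is made for them only; others in the source may bear on it.

Working notes on the series. In a physicochemical assay for solubility, read by HPLC, using the shake flask method, measured as kinetic solubility, with a stated time of 20 h, at pH 6.5, tested at 200 uM (on this read-out higher numbers stand for higher solubility and lower numbers for lower solubility), compound 1 (`C[C@@H](CO)NS(=O)(=O)c1cccc(-c2ccc3nccc(-c4ccncc4)c3n2)c1`) gives 50000 nM and compound 3 (`NS(=O)(=O)c1ccc(-c2ccc3nccc(-c4ccncc4)c3n2)cc1`) gives 25000 nM, two values within the usual scatter of each other. Compound 2 (`O=S(=O)(NCCO)c1cccc(-c2ccc3nccc(-c4ccc(OC(F)(F)F)cc4)c3n2)c1`) gives only a limit, < 5000 nM. Compound 4 (`C[C@@H]1CN(S(=O)(=O)c2cccc(-c3ccc4nccc(-c5ccncc5)c4n3)c2)C[C@H](C)N1`) carries 3,5-dimethylpiperazin-1-yl in place of (1-(hydroxymethyl)ethyl)amino on a sulfonyl sulfur. Among the compounds with values here, no measured pair covers this change, so the expectation starts from compound 1 at 50000 nM. A small upward step that stays within the scatter is expected, estimated as a 1.2-fold higher number from compound 1 to compound 4 (0.08 log units; within the scatter). The estimate for compound 4 is 60000 nM, with an expected range of 15000 nM to 180000 nM.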

Compound 4, solubility: 180000 nM
Beside the measured number, compound 4's estimate is 3.0-fold (0.48 log units) below it; measured number inside the range.
By their numbers in this assay, from the lowest: compounds 3 and 1 (each within the scatter of the next); then compound 4. At a limit, below all of these: compound 2.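

In this assay, within the data shown here, the exchange of (1-(hydroxymethyl)ethyl)amino for 3,5-dimethylpiperazin-1-yl on a sulfonyl sulfur is the first readable step, and it gives a 3.6-fold higher number from compound 1 to compound 4 (0.56 log units; beyond the scatter) as a modest change. This position therefore accepts a six-membered non-aromatic ring in place of an open group, with no loss on this read-out. Nothing measured here accounts for the step.

On these data alone, whether the step belongs to the ring itself or to its two methyl groups stays open. Unsubstituted piperazin-1-yl and morpholin-4-yl on the same sulfonyl sulfur would separate these.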